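A few compounds are considered here, and "the series" means these few. Any claim that something is new, unique, unknown or untested is made for them only; others in the source may bear on it.

Among the measured compounds shown here, compound 3 `COc1ccc(-c2cn(/N=C/c3cc4cc(C)ccc4nc3Cl)c(N)n2)cc1` is the one compound of the three measured that returns a number in a functional assay on MDA-MB-231 cells (Homo sapiens) for cytotoxicity, read by MTT assay, with a stated time of 48 h; a lower number here means a stronger inhibitor, a higher number a weaker inhibitor: compound 3 gives 23600 nM. Compound 1 `COc1ccc(-c2cn(/N=C/c3cc4ccccc4nc3Cl)c(N)n2)cc1` sits at a limit of the assay, > 50000 nM, not at a number. Compound 2 `Nc1nc(-c2ccc(Br)cc2)cn1/N=C/c1cc2ccccc2nc1Cl` likewise sits at a limit, > 50000 nM. From compound 1 to compound 3 the change is a methyl in place of a hydrogen on an aromatic carbon, and this assay gives an at least 2.1-fold lower number from compound 1 to compound 3 (0.32 log units; beyond the scatter). Compound 4 `Cc1ccc2nc(Cl)c(/C=N/n3cc(-c4ccc(Br)cc4)nc3N)cc2c1` has not yet been measured. It differs from compound 3 by bromo in place of methoxy on an aromatic carbon. The same change was made once before, from compound 1 to compound 2, where this assay gives a step that the two limits leave unreadable from compound 1 to compound 2 because the limit of > 50000 nM in this assay, at which 2 of the 3 values shown sit, hides its size. No readable step therefore speaks for this change, and the expected step is a 1.3-fold higher number from compound 3 to compound 4 (0.10 log units; within the scatter), nothing beyond the usual scatter, with a fair chance that this assay again reports only a limit. Compound 4 is therefore expected to give 30000 nM in this assay, in a range from 10000 nM to 100000 nM.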

Compound 4, half-maximal inhibitory concentration: 38200 nM
The estimate for compound 4 lay 1.3-fold (0.10 log units) below the measured number; the range from low to high includes it.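

Among the compounds shown here, the change from 4-methoxyphenyl to 4-bromophenyl can now be read for the first time in this assay, as a 1.6-fold higher number from compound 3 to compound 4 (0.21 log units; within the scatter), so on this core the two groups cannot be told apart at this position. The methyl in place of hydrogen also gains a second example, an at least 1.3-fold lower number from compound 2 to compound 4 (0.11 log units; that floor lies within the scatter), though this is only a floor set by a limit. Both examples point the same way, but their sizes cannot be compared: the same change on two cores in this assay, an at least 2.1-fold lower number (0.32 log units; beyond the scatter) from compound 1 to compound 3 and an at least 1.3-fold lower number (0.11 log units; that floor lies within the scatter) from compound 2 to compound 4; the limit leaves it open whether they differ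

The compounds shown leave open whether an amine or a carboxylic acid at this position would shift the number beyond the scatter. How far compound 1 and compound 2 truly lie from the others also stays open, since neither gives a number: the limit of > 50000 nM in this assay, at which 2 of the 4 values shown sit.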